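This account rests on a few compounds, and the source may have more. Where it says the series, first, only, none or still open, it means among the compounds named here.

Compound 2 `CC(C)(C)n1ncc(OCc2nnc(-c3ccccc3F)o2)c(Cl)c1=O` belongs to a small pair of compounds in which one aromatic group hangs off a shared core. In a functional assay on the whole organism for inhibition, with Mythimna separata as the target, with a stated time of 5 days (on this read-out higher numbers stand for an effect only at larger amounts of compound and lower numbers for an effect already at smaller amounts), compound 2 gives 16800 nM. Among the measured compounds shown here, its only neighbour is compound 1 `COc1ccc(-c2nnc(COc3cnn(C(C)(C)C)c(=O)c3Cl)o2)cc1`, which in this assay gives 17700 nM; the two numbers sit within the scatter of each other, so neither can be called stronger. The step of a 1.1-fold lower number from compound 1 to compound 2 (0.02 log units; within the scatter) shows that exchanging one aromatic ring for another left the read-out where it was. Compound 3 `CC(C)(C)n1ncc(OCc2nnc(-c3ccco3)o2)c(Cl)c1=O` differs from compound 2 by furan-2-yl in place of 2-fluorophenyl on an aromatic carbon. For the measured compounds named here, this is again an exchange of the aromatic group at the same place on the core, and the single comparable step, from compound 1 to compound 2, stayed within the scatter. No step beyond the scatter is therefore expected. The estimate for compound 3 in this assay is 17000 nM, with a range from 6000 nM to 50000 nM, which means an expected step of a 1.0-fold higher number from compound 2 to compound 3 (0.01 log units; within the scatter).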

Compound 3, half-maximal effective concentration: > 299000 nM
Compound 3 gave a limit, no number; the forecaster's own chance of this, stated with the estimate: 10%; at least 17-fold (1.24 log units) between middle value and limit.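

Up to now, the position on the five-membered ring looked tolerant, since 2-fluorophenyl and 4-methoxyphenyl read the same within the scatter. Compound 3 shows that this tolerance does not extend to every aromatic group: in this assay, furan-2-yl brings an at least 17-fold higher number from compound 2 to compound 3 (1.25 log units; beyond the scatter) and an at least 16-fold higher number from compound 1 to compound 3 (1.22 log units; beyond the scatter), so a much larger amount of compound is needed for an effect. The value of compound 3 is a limit, not a number: the limit of > 299000 nM in this assay, at which 1 of the 3 values shown sits.

The compounds shown do not separate the effect of the smaller five-membered ring from that of its ring oxygen, and a thiophen-2-yl group, with sulfur in place of that oxygen, would help to tell the two apart. From the compounds shown here alone, how an unsubstituted phenyl, an amine or a longer chain would read at this place also remains open.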